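Mirror-image configuration of a cinnamate ester in Jurkat cytotoxicity

The source may hold more compounds than are shown below. What is called first, only, known or untested is meant among the compounds shown, and "the series" means these compounds.

Measured compounds:
- compound 1, `O=C1C[C@@H]2O[C@@H]([C@H](O)c3ccccc3)[C@@H](O)[C@@H]2O1`: 50 nM
- compound 2, `O=C(/C=C/c1ccccc1)O[C@H](c1ccccc1)[C@H]1O[C@@H]2CC(=O)O[C@@H]2[C@H]1O`: 25500 nM

Of the compounds shown here, two have been tested in a functional assay on Jurkat cells (Homo sapiens) for cytotoxicity, read by MTT assay, with a stated time of 72 h; on this read-out lower numbers stand for stronger inhibition and higher numbers for weaker inhibition. Compound 1 gives 50 nM, and compound 2 gives 25500 nM. Compound 2 therefore has the higher of the two numbers, and its gap to compound 1 lies beyond the scatter of repeated measurements, so compound 2 is the weaker of the two in this assay. The two structures differ in several places at once, so no single change can be tied to that gap.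

Compound 3, `O=C(/C=C/c1ccccc1)O[C@@H](c1ccccc1)[C@@H]1O[C@H]2CC(=O)O[C@H]2[C@@H]1O`, has not yet been measured. It differs from compound 2 as follows: the two compounds have the same atoms and bonds and differ only in configuration as drawn: 5 of 6 stereo elements differ; a stereocentre at a saturated chain carbon is drawn R in compound 2 and S in compound 3; a stereocentre at a saturated ring carbon is drawn S in compound 2 and R in compound 3; a stereocentre at a saturated ring carbon is drawn R in compound 2 and S in compound 3; a stereocentre at a saturated ring carbon is drawn R in compound 2 and S in compound 3. Among the measured compounds there is no pair that differs only in configuration, so there is no directly comparable step to lean on. The expectation is that compound 3 is estimated to give 15000 nM, with a range from 3000 nM to 60000 nM, which corresponds to an expected step from compound 2 to compound 3 of a 1.7-fold lower number from compound 2 to compound 3 (0.23 log units; within the scatter); the direction is uncertain, and a step within the scatter is possible.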

Compound 3, half-maximal inhibitory concentration: 15700 nM
Estimate against measurement, compound 3: 1.0-fold (0.02 log units) below; the measured number falls inside the stated range.
By their numbers in this assay, from the lowest: compound 1; then compounds 3 and 2 (each within the scatter of the next).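

Compounds 2 and 3 are the first pair here that can be compared directly, because the atoms and bonds stay the same and only the arrangement in space changes: the fact that compounds 2 and 3 differ only in the configuration as drawn

In this assay, this pair gives a 1.6-fold lower number from compound 2 to compound 3 (0.21 log units; within the scatter), so the change in configuration, which touches the chain carbon bearing the cinnamate ester as well as saturated ring carbons, produces no difference that can be told apart from ordinary repeat variation. Going by these compounds alone, for these two cinnamate esters, then, the configuration as drawn does not separate the compounds on this read-out, and neither compound can be ranked above the other, although this finding covers only this one pair.

Whether configuration would matter just as little for the core of compound 1, which gives 50 nM, remains an open question, and the large gap between that compound and the two cinnamate esters still cannot be tied to any single structural change. On these data alone, it is also open whether an amide in place of the cinnamate ester, or a longer chain in the acyl part, would give a number closer to that of compound 1.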